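A few compounds are considered here, and "the series" means these few. Any claim that something is new, unique, unknown or untested is made for them only; others in the source may bear on it.

Measured in a toxicity assay on Vero cells (Chlorocebus sabaeus) for cytotoxicity, read by MTT assay; a higher number here means a weaker inhibitor, a lower number a stronger inhibitor:
- Compound 1 `COC(=O)NC(=O)c1ccsc1NC(=O)c1ccc(S(=O)(=O)N2CCCCCC2)cc1`: 9.13 ug/mL
- Compound 2 `COC(=O)NC(=O)c1ccsc1NC(=O)c1ccc(S(=O)(=O)N2CCC(c3ccccc3)CC2)cc1`: "nd" (no result reported)
- Compound 3 `COC(=O)NC(=O)c1ccsc1NC(=O)c1ccc(S(=O)(=O)NC2CCCCC2)cc1`: > 64 ug/mL

Compound 3 carries only a limit of the assay, > 64 ug/mL, and no number. Compound 4 `CCN(C)S(=O)(=O)c1ccc(C(=O)Nc2sccc2C(=O)NC(=O)OC)cc1` awaits measurement. It differs from compound 3 by ethyl(methyl)amino in place of cyclohexylamino on a sulfonyl sulfur. Among the compounds with values here, one measured step bears on this change: an at least 7.0-fold higher number from compound 1 to compound 3 (0.84 log units; beyond the scatter), with cyclohexylamino in place of azepan-1-yl on a sulfonyl sulfur. That step lies beyond the scatter. Removing cyclohexylamino may partly reverse it, so a move towards a lower number is expected, though this rests on a single step. The expected change is an at least 2.5-fold lower number from compound 3 to compound 4 (0.40 log units; beyond the scatter). The estimated value for compound 4 is 25 ug/mL, with an expected range of 8 ug/mL to 64 ug/mL.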

Compound 4, half-maximal inhibitory concentration: 10.4 ug/mL
For compound 4 the middle estimate is 2.4-fold (0.38 log units) above the measured one; the range from low to high includes it.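

In this assay, ethyl(methyl)amino and azepan-1-yl on a sulfonyl sulfur read alike, at a 1.1-fold higher number from compound 1 to compound 4 (0.06 log units; within the scatter). Against cyclohexylamino, the same open-chain group gives an at least 6.1-fold lower number from compound 3 to compound 4 (0.78 log units; beyond the scatter), so among these three compounds only compound 3 stands apart. The value of compound 3, > 64 ug/mL, is a limit of the assay, so this step has no upper end: the limit of > 64 ug/mL in this assay, at which 1 of the 4 values shown sits.

Within the data shown here, compound 2 gives no number, so no step to it can be read. As far as these compounds go, whether cyclohexyl(methyl)amino or a longer chain such as dipropylamino on the sulfonyl sulfur would read with compound 3 or with compound 4 stays open.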